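This account rests on a few compounds, and the source may have more. Where it says the series, first, only, none or still open, it means among the compounds named here.

Series notes. Three compounds share one core, a sugar-bearing bicyclic system carrying an aryl group on the five-membered ring. Compound 1 `COc1nc(N)nc2c1c(-c1cc3ccccc3o1)cn2[C@@H]1O[C@H](CO)[C@@H](O)[C@H]1O` gives 25600 nM in an ADME assay on BJ cells (Homo sapiens), read by MTT assay, with a stated time of 72 h; on this read-out lower numbers stand for stronger inhibition and higher numbers for weaker inhibition. Compound 2 `Nc1nc(N)c2c(-c3cc4ccccc4o3)cn([C@@H]3O[C@H](CO)[C@@H](O)[C@H]3O)c2n1` comes back in this assay only as a limit, > 100000 nM. Compound 3 `Cc1nc(N)c2c(-c3cc4ccccc4o3)cn([C@@H]3O[C@H](CO)[C@@H](O)[C@H]3O)c2n1` likewise returns only a limit in this assay, > 100000 nM. The change of an at least 3.9-fold higher number from compound 1 to compound 2 (0.59 log units; beyond the scatter) is therefore a minimum, and the change of a step that the two limits leave unreadable from compound 2 to compound 3 cannot be sized at all, since both of its ends sit at the limit of > 100000 nM in this assay, at which 2 of the 3 values shown sit. Compound 2 thus stands at the weak end of everything measured so far, with no number of its own, only the limit.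

Compound 4 `Nc1nc(N)c2c(-c3cccs3)cn([C@@H]3O[C@H](CO)[C@@H](O)[C@H]3O)c2n1` is not yet measured; it differs from compound 2 by thiophen-2-yl in place of 1-benzofuran-2-yl on an aromatic carbon. For the measured compounds named here, no measured step touches this change: each of the measured steps swaps a small group on an aromatic carbon of the core and leaves the aryl group untouched, so nothing among the numbers speaks to exchanging it. Going by the values given here, the only guide is that compound 2 itself sits at the limit. For compound 4 in this assay no step beyond the scatter is expected in either direction, a number no higher from compound 2 to compound 4 (the limit leaves the size open). Compound 4 is estimated at 100000 nM, with a range from 30000 nM to 300000 nM, and most likely reported again as a limit rather than a number.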

Compound 4, half-maximal inhibitory concentration: > 100000 nM
Compound 4 was reported as a limit; the forecaster's own chance of this, stated with the estimate: 70%; the middle value sits exactly at the limit.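

Compound 4 returns only a limit in this assay, > 100000 nM, so no step can be read between compound 2 and compound 4, and both stand at the same limit: the limit of > 100000 nM in this assay, at which 3 of the 4 values shown sit. Left open is whether exchanging 1-benzofuran-2-yl for thiophen-2-yl changes the response at all, since neither compound 2 nor compound 4 has a number of its own.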